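From compound 1 to a branched chain in compound 4

The compounds below may be only part of what the source reports. "The series", "measured", "known", "first", "only" and "open" are said of these compounds alone.

compound 1 `O=C(CCCOc1no[n+]([O-])c1S(=O)(=O)c1ccccc1)NO` gives 1480 nM
compound 2 `O=C(CCCCCCOc1no[n+]([O-])c1S(=O)(=O)c1ccccc1)NO` gives 4270 nM
compound 3 `O=C(CCCCCCCOc1no[n+]([O-])c1S(=O)(=O)c1ccccc1)NO` gives 630 nM

These three values come from a functional assay on KG-1 cells (Homo sapiens) for inhibition, read by MTT assay, with a stated time of 48 h (on this read-out higher numbers stand for weaker inhibition and lower numbers for stronger inhibition), and the compounds differ only in the chain carrying the hydroxycarbamoyl group. Compound 1 sits in the middle of the three, with compound 3 lower and compound 2 higher. Compound 4 `CC(C)(COc1no[n+]([O-])c1S(=O)(=O)c1ccccc1)C(=O)NO` keeps the shared core and changes only that chain (1-(hydroxycarbamoyl)-1-methylethyl in place of 2-(hydroxycarbamoyl)ethyl on a saturated chain carbon bound to an oxygen on an aromatic ring), on a saturated chain carbon bound to an oxygen on an aromatic ring.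

For the measured compounds named here, no measured step tests a branched chain, so the nearest evidence is chain length. The steps are a 2.9-fold higher number from compound 1 to compound 2 (0.46 log units; beyond the scatter) and a 2.3-fold lower number from compound 1 to compound 3 (0.37 log units; beyond the scatter) and a 6.8-fold lower number from compound 2 to compound 3 (0.83 log units; beyond the scatter), all modest yet beyond the scatter. Lengthening the chain raises the number at compound 2 but lowers it at compound 3, so they show no single trend. They do suggest how large a chain change can be here. Going by the values given here, the direction is only a weak lean, taken from the one upward step, a 2.9-fold higher number from compound 1 to compound 2 (0.46 log units; beyond the scatter) in the same assay. On that basis, the estimated change in this assay is a 2.2-fold higher number from compound 1 to compound 4 (0.33 log units; beyond the scatter) and is expected to be modest. For compound 4 the estimated value is 3200 nM with 900 nM to 10000 nM as the expected range.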

Compound 4, half-maximal inhibitory concentration: 6080 nM
Estimate against measurement, compound 4: 1.9-fold (0.28 log units) below, and the stated range covers the measured number.
By their numbers in this assay, from the lowest: compound 3; then compound 1; then compounds 2 and 4 (each within the scatter of the next).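

In this assay the move to a branched chain gives a 4.1-fold higher number from compound 1 to compound 4 (0.61 log units; beyond the scatter) and so weaker inhibition, which shows that this position responds to the shape of the chain as well as to its length. The change is small by count, with 7 heavy atoms in 1-(hydroxycarbamoyl)-1-methylethyl against 6 in 2-(hydroxycarbamoyl)ethyl and no ring or net charge in either, yet it is enough to take the number beyond the scatter and leave compound 4 within the scatter of compound 2, which has the unbranched, longer chain. Nothing available here explains why this branched chain gives the higher number.

Going by these compounds, it remains open whether a smaller branch, such as 1-(hydroxycarbamoyl)ethyl, would give a similar step, or whether a cyclopropane ring at the same carbon would behave in the same way. For the compounds shown here, it is also unclear whether the same branching on a longer chain, such as the one in compound 3, would raise the number too, so the result so far rests on a single pair of compounds.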